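This account rests on a few compounds, and the source may have more. Where it says the series, first, only, none or still open, it means among the compounds named here.

Measured so far in a physicochemical assay for solubility, in phosphate buffer, with a stated time of 18 h; on this read-out higher numbers stand for higher solubility and lower numbers for lower solubility:
- compound 1 `Cc1ncc2c(N)c(C#N)c(N)nc2n1`: 783000 nM
- compound 2 `N#Cc1c(N)nc2nc(C3CCCC3)ncc2c1N`: 89000 nM
- compound 3 `N#Cc1c(N)nc2nc(C3CCCCC3)ncc2c1N`: 81000 nM

Compound 3 sits at the low end of these numbers. Its nearest neighbour shows a 1.1-fold lower number from compound 2 to compound 3 (0.04 log units; within the scatter), while the methyl compound shows a 9.7-fold lower number from compound 1 to compound 3 (0.99 log units; beyond the scatter).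

The next compound, compound 4 `N#Cc1c(N)nc2nc(Cc3ccccc3)ncc2c1N`, has benzyl in place of cyclohexyl on an aromatic carbon.

For the measured compounds named here, no measured step involves a benzyl group, so the guidance is indirect. Replacing methyl gave a modest drop, an 8.8-fold lower number from compound 1 to compound 2 (0.94 log units; beyond the scatter), whereas exchanging cyclopentyl for cyclohexyl gave a 1.1-fold lower number from compound 2 to compound 3 (0.04 log units; within the scatter). A ring-for-ring exchange is therefore expected to stay small in this assay, perhaps slightly downward, with no firm direction.

The expected change is a 1.4-fold lower number from compound 3 to compound 4 (0.13 log units; within the scatter).

For compound 4, the estimate is 60000 nM, with an expected range of 22000 nM to 150000 nM.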

Compound 4, solubility: 13000 nM
Beside the measured number, compound 4's estimate is 4.6-fold (0.66 log units) above it; measured number below the stated range.
By their numbers in this assay, from the lowest: compound 4; then compounds 3 and 2 (each within the scatter of the next); then compound 1.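

In this assay, this position proved sensitive to the type of ring it carries: the cyclopentyl and cyclohexyl compounds lie within the scatter of each other, yet benzyl gives a 6.2-fold lower number from compound 3 to compound 4 (0.79 log units; beyond the scatter) and a 6.8-fold lower number from compound 2 to compound 4 (0.84 log units; beyond the scatter). The largest step among these compounds is a 60-fold lower number from compound 1 to compound 4 (1.78 log units; beyond the scatter), where phenyl replaces hydrogen on a saturated chain carbon bound to an aromatic carbon. No supporting data explain the difference between benzyl and the saturated rings.

On these data alone, it remains open whether a pyridine ring on the same chain carbon, or a phenyl group attached directly to the aromatic carbon, would give a number closer to that of compound 4 or compound 3.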